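The compounds below may be only part of what the source reports. "The series", "measured", "known", "first", "only" and "open" are said of these compounds alone.

Measured so far in a functional assay on HO8910 cells (Homo sapiens) for cytotoxicity, read by CCK-8 assay, with a stated time of 24 h; a higher number here means a weaker inhibitor, a lower number a stronger inhibitor:

Compound 1 `C/C(=C\c1cc(-c2ccccc2)cs1)C(N)=O` gives > 50000 nM, which is a limit of the assay and not a number.
Compound 2 `C/C(=C\c1cc(-c2ccc(C)cc2)cs1)C(N)=O` gives > 50000 nM, again a limit of the assay.
Within the data shown here, compound 3 `C/C(=C\c1cccc(-c2ccccc2)c1)C(N)=O` gives 12600 nM, the only number in the set.

The change from compound 1 to compound 2 is methyl in place of hydrogen on an aromatic carbon. Its step, a step that the two limits leave unreadable from compound 1 to compound 2, cannot be read because of the limit of > 50000 nM in this assay, at which 2 of the 3 values shown sit. The difference between the core of compound 1 and the core of compound 3 is not broken down here.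

Compound 4 `C/C(=C\c1cccc(-c2ccc(C)cc2)c1)C(N)=O` carries the same change on the core of compound 3: methyl in place of hydrogen on an aromatic carbon. Both place descriptions agree word for word, so this is the same change made twice, though only compound 3 offers a readable starting value. With no readable precedent for the step, the expectation is that it stays within the usual scatter of this assay, so compound 4 is estimated at 12000 nM, between 5000 nM and 32000 nM. The expected step from compound 3 is a 1.1-fold lower number from compound 3 to compound 4 (0.02 log units; within the scatter), resting on compound 3 giving 12600 nM.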

Compound 4, half-maximal inhibitory concentration: 26800 nM
The estimate for compound 4 lay 2.2-fold (0.35 log units) below the measured number; measured number inside the range.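

In this assay, among these compounds, methyl in place of hydrogen on an aromatic carbon, para to a large group, gives a 2.1-fold higher number from compound 3 to compound 4 (0.33 log units; beyond the scatter), a modest step and the only readable instance of this change. The same change on the core of compound 1, leading to compound 2, cannot be read, as both compounds sit at a limit of the assay and not at a number: the limit of > 50000 nM in this assay, at which 2 of the 4 values shown sit. The step on the core of compound 3 therefore gives a direction and size for that core alone, and it neither confirms nor rules out that the change carries over to the core of compound 1.

On these data alone, whether an ethyl, a methoxy or a trifluoromethyl group at the same place moves the number in the same direction as methyl remains open. Also open, as far as these compounds go, is what a carboxylic acid in place of the amide would do on either core.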